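Extending the selenium chain motif across the shared core

This account rests on a few compounds, and the source may have more. Where it says the series, first, only, none or still open, it means among the compounds named here.

Compound 1 `CCCCC[Se]c1nc(N)c2ccccc2n1` is measured in a functional assay on HT-29 cells (Homo sapiens) for cytotoxicity, read by MTT assay, with a stated time of 72 h (a higher number here means a weaker inhibitor of growth, a lower number a stronger inhibitor of growth), where compound 1 gives 40300 nM. Compound 2 `C[Se]c1nc(N)c2ccccc2n1` in this assay gives 27600 nM. Among the measured compounds shown here, the only step so far, a 1.5-fold lower number from compound 1 to compound 2 (0.16 log units; within the scatter), concerns hydrogen in place of butyl on a saturated chain carbon bound to a selenium atom; it is within the scatter, so the two measured compounds sit together and neither can be called the stronger.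

Compound 3 `CCCCC[Se]c1nc([Se]CCCCC)c2ccccc2n1` differs from compound 1 by a group of 6 heavy atoms (5 carbon, 1 selenium; no ring) in place of one nitrogen atom, on an aromatic carbon. For the measured compounds named here, no measured step touches this place: the one step available alters the chain at the selenium, not the amino on the aromatic carbon, and it was itself within the scatter. There is therefore no measured basis for a direction, and the estimate can only stay near the measured pair with a wide range. Compound 3 is expected at 55000 nM, between 18000 nM and 160000 nM, which means an expected step of a 1.4-fold higher number from compound 1 to compound 3 (0.14 log units; within the scatter).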

Compound 3, concentration for 50% growth inhibition: > 100000 nM
Compound 3: only a limit was reported (the forecaster's own chance of this, stated with the estimate: 25%); at least 1.8-fold (0.25 log units) between middle value and limit.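

Among the compounds shown here, the aromatic carbon carrying the amino group is the first place where a change reads beyond the scatter: replacing that amino group with the group of 6 heavy atoms (5 carbon, 1 selenium; no ring) gives an at least 2.4-fold higher number from compound 1 to compound 3 (0.39 log units; beyond the scatter). The earlier step at the chain on selenium gave no such separation. For compound 3 in this assay, the reading is a limit and not a number: the limit of > 100000 nM in this assay, at which 1 of the 3 values shown sits.

This step therefore fixes a direction at this position, toward weaker inhibition of growth, but only a minimum for its size. It also removes the amino group and brings in the selenium chain in one change, so the two contributions remain unseparated. A methylamino group or a hydroxyl on this same carbon would show how this position reads with a smaller replacement.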